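Fluoro to methoxy: working notes on compound 4

The compounds below may be only part of what the source reports. "The series", "measured", "known", "first", "only" and "open" are said of these compounds alone.

Measured in a functional assay on MIA PaCa-2 cells (Homo sapiens) for cytotoxicity, read by WST assay, with a stated time of 24 h; on this read-out lower numbers stand for stronger inhibition and higher numbers for weaker inhibition:
- compound 1 `COc1ccc2c(/C=C(\C#N)C(=O)c3c[nH]c4cc(F)ccc34)c[nH]c2c1`: > 50000 nM (a limit)
- compound 2 `COc1ccc2c(/C=C(\C#N)C(=O)c3c[nH]c4cc(OC)ccc34)c[nH]c2c1`: > 50000 nM (a limit)
- compound 3 `N#C/C(=C\c1c[nH]c2cc(F)ccc12)C(=O)c1c[nH]c2ccccc12`: 23500 nM

Not yet measured: compound 4 `COc1ccc2c(/C=C(\C#N)C(=O)c3c[nH]c4ccccc34)c[nH]c2c1`.

Within the data shown here, compound 3 gives 23500 nM, the only true number in the set. The other two readings are limits. The next step replaces fluoro with methoxy on an aromatic carbon, giving compound 4: methoxy in place of fluoro on an aromatic carbon.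

Among the measured compounds shown here, the only measured change of the same kind is a step that the two limits leave unreadable from compound 1 to compound 2. As far as these compounds go, its size stays open because of the limit of > 50000 nM in this assay, at which 2 of the 3 values shown sit. That step therefore supplies no magnitude and no direction to carry over. No shift beyond the scatter is expected in this assay, although a reading that is only a limit remains possible. The estimated step is a 1.3-fold higher number from compound 3 to compound 4 (0.11 log units; within the scatter). For compound 4 the expected value is 30000 nM, with an estimated range of 12000 nM to 50000 nM.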

Compound 4, half-maximal inhibitory concentration: 27500 nM
The estimate for compound 4 lay 1.1-fold (0.04 log units) above the measured number; the range from low to high includes it.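

In this assay, methoxy in place of fluoro on an aromatic carbon now has a readable size, a 1.2-fold higher number from compound 3 to compound 4 (0.07 log units; within the scatter), whereas the earlier pair of compounds gave no size at all. At the site where compound 4 carries hydrogen, hydrogen in place of methoxy gives an at least 1.8-fold lower number from compound 2 to compound 4 (0.25 log units; that floor lies within the scatter), and hydrogen in place of fluoro gives an at least 1.8-fold lower number from compound 1 to compound 4 (0.25 log units; that floor lies within the scatter). Both of these steps are floors within the scatter and show no shift beyond it, as they rest on a limit: the limit of > 50000 nM in this assay, at which 2 of the 4 values shown sit.

As far as these compounds go, the true size of those two steps remains open, as does whether the swap from fluoro to methoxy would keep its size in compounds with a different group at the other site. Also open, from the compounds shown here alone, is whether an amine or a carboxylic acid on this aromatic carbon would move the number beyond the scatter.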